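The source may report more compounds than this note shows. Statements on the series, on what has been measured and on what is new or still open speak of the compounds shown alone.

Going by the values given here, compound 1 `CC1(C)C=C(n2ccccc2=O)c2cc(S(N)(=O)=O)ccc2O1` gives 92.1% in a functional assay on the whole organism (trachea) with Rattus norvegicus as the target (a lower number here means a smaller maximal response, a higher number a larger maximal response), the highest of the three numbers measured so far, although neither neighbour is separated from it beyond the scatter: the step is a number 4.2 percentage points lower from compound 1 to compound 3 (within the scatter) to compound 3 `CC1(C)C=C(n2ccccc2=O)c2cc(S(=O)(=O)NCCO)ccc2O1` with 87.9%, and a number 5.1 percentage points lower from compound 1 to compound 2 (within the scatter) to compound 2 `CCNS(=O)(=O)c1ccc2c(c1)C(n1ccccc1=O)=CC(C)(C)O2` with 87%. Between those two the step is a number 0.9 percentage points higher from compound 2 to compound 3 (within the scatter).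

Compound 4 `CC1(C)C=C(n2ccccc2=O)c2cc(S(=O)(=O)NC(=O)Nc3ccccc3)ccc2O1` differs from compound 1 by phenylcarbamoyl in place of hydrogen on a sulfonamide nitrogen. Among the compounds with values here, two measured steps touch the same sulfonamide nitrogen: ethyl in place of hydrogen gave a number 5.1 percentage points lower from compound 1 to compound 2 (within the scatter), and 2-hydroxyethyl in place of hydrogen gave a number 4.2 percentage points lower from compound 1 to compound 3 (within the scatter), both within the scatter. Phenylcarbamoyl is a larger group than either, so those steps cover the change only in part, and the range of the estimate is set wider for that reason. One therefore expects for compound 4 a step of a number 6.1 percentage points lower from compound 1 to compound 4 (within the scatter) in this assay, nothing beyond the scatter in either direction. The estimate for compound 4 is 86%, with a range from 70% to 97%.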

Compound 4, largest response reached (Emax), in percent of the reference or control that the assay uses: 99.5%
The estimate for compound 4 lay 13.5 percentage points below the measured number; measured number above the stated range.
By their numbers in this assay, from the lowest: compounds 2, 3, 1 and 4 (each within the scatter of the next, the first and the last beyond it).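

At the sulfonamide nitrogen, phenylcarbamoyl in place of hydrogen does not separate compound 4 from the unsubstituted sulfonamide in this assay, with a number 7.4 percentage points higher from compound 1 to compound 4 (within the scatter). Against the two smaller substituents on that nitrogen, however, it gives the first separations beyond the scatter in this set, though modest ones, with a number 11.6 percentage points higher from compound 3 to compound 4 (beyond the scatter) and a number 12.5 percentage points higher from compound 2 to compound 4 (beyond the scatter). No measurement given here bears on the origin of these differences.

On these data alone, it remains open which part of phenylcarbamoyl matters: an acetyl group on the same nitrogen would keep the carbonyl without the phenyl ring, and a benzyl group the ring without the carbonyl. Also open, as far as these compounds go, is whether a chloro or methoxy group on that phenyl ring would leave the response in this assay where compound 4 stands.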